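The source may report more compounds than this note shows. Statements on the series, on what has been measured and on what is new or still open speak of the compounds shown alone.

Measured compounds:
Compound 1 `CN(C)[C@H]1C[C@H](c2c[nH]c3ccc(C(=O)NCc4ccccc4)cc32)C1` — in an assay on CHO-K1 cells for binding affinity to 5-hydroxytryptamine receptor 1D (Homo sapiens) (a lower number here means a stronger inhibitor, a higher number a weaker inhibitor), compound 1 gives 141 nM.
Compound 2 `Cc1noc(Cc2ccc3[nH]cc([C@H]4C[C@H](N(C)C)C4)c3c2)n1` — in this assay compound 2 gives 933 nM.
Compound 3 `CN(C)[C@H]1C[C@H](c2c[nH]c3ccc(CC(N)=O)cc32)C1` — in this assay compound 3 gives 724 nM.

Compound 2 has the highest number of the three, so it is the weakest inhibitor of this small set. Its nearest neighbour is compound 3, whose step a 1.3-fold lower number from compound 2 to compound 3 (0.11 log units; within the scatter) lies within the scatter, so the two cannot be told apart. Compound 1 is the furthest away, with a number well below that of compound 2.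

Compound 4 `CN(C)[C@H]1C[C@H](c2c[nH]c3ccc(CN4C(=O)CNC4=O)cc32)C1` has not yet been measured. It differs from compound 2 in one place: 2,5-dioxoimidazolidin-1-yl in place of 3-methyl-1,2,4-oxadiazol-5-yl on a saturated chain carbon bound to an aromatic carbon. Going by the values given here, the only measured step that speaks to this kind of change is the one from compound 2 to compound 3, where a carbamoyl took the place of the same 3-methyl-1,2,4-oxadiazol-5-yl, and that step a 1.3-fold lower number from compound 2 to compound 3 (0.11 log units; within the scatter) stayed within the scatter. The entering 2,5-dioxoimidazolidin-1-yl shares with carbamoyl a hydrogen-bond donor and a carbonyl, so a similar outcome is expected, with no step beyond the scatter in this assay.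

For compound 4 the expected value in this assay is 750 nM, in the range 300 nM to 2000 nM, which would be an estimated step of a 1.2-fold lower number from compound 2 to compound 4 (0.09 log units; within the scatter).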

Compound 4, half-maximal inhibitory concentration: 2450 nM
Beside the measured number, compound 4's estimate is 3.3-fold (0.51 log units) below it; the whole stated range lies below it.
By their numbers in this assay, from the lowest: compound 1; then compounds 3 and 2 (each within the scatter of the next); then compound 4.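

On a saturated chain carbon bound to an aromatic carbon, the earlier pair left 3-methyl-1,2,4-oxadiazol-5-yl and carbamoyl indistinguishable in this assay, but this change shows that the group placed there can shift the number, with a 2.6-fold higher number from compound 2 to compound 4 (0.42 log units; beyond the scatter) and a 3.4-fold higher number from compound 3 to compound 4 (0.53 log units; beyond the scatter). Both steps are modest yet beyond the scatter, so sharing a hydrogen-bond donor and a carbonyl with carbamoyl did not keep 2,5-dioxoimidazolidin-1-yl level with it. Nothing available here explains this rise in the number.

These compounds cannot tell whether the rise belongs to the whole non-aromatic ring or to one part of it. Going by these compounds, how an amine or a carboxylic acid would compare in this place remains open, as does a longer chain carrying 2,5-dioxoimidazolidin-1-yl.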